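Replacing the substituted pyrazole: a step without precedent

A few compounds are considered here, and "the series" means these few. Any claim that something is new, unique, unknown or untested is made for them only; others in the source may bear on it.

Two close analogues have been measured in an in vitro assay on HEK293 cells for displacement of a labelled ligand from adenosine receptor A2b (Homo sapiens); on this read-out lower numbers stand for stronger inhibition and higher numbers for weaker inhibition. Compound 1 `CCCn1c(=O)c2nc(-c3cc(C)nn3CC)[nH]c2n(CCC)c1=O` gives 2100 nM, and compound 2 `CCCn1c(=O)c2nc(-c3cc(C)nn3C)[nH]c2n(CCC)c1=O` gives 3700 nM, the higher of these two numbers, although the step of a 1.8-fold higher number from compound 1 to compound 2 (0.25 log units; within the scatter) lies within the scatter. Compound 3 `CCCn1c(=O)c2nc(-n3cccn3)[nH]c2n(CCC)c1=O` carries 1H-pyrazol-1-yl in place of 1,3-dimethyl-1H-pyrazol-5-yl on an aromatic carbon. Within the data shown here, no measured step tests this change directly; the only measured step removed a single methyl and hardly moved the number, whereas this change removes both methyls and alters the point of attachment. Compound 3 is therefore expected to give 5000 nM, between 1500 nM and 20000 nM, with an expected step of a 1.4-fold higher number from compound 2 to compound 3 (0.13 log units; within the scatter) that remains uncertain.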

Compound 3, inhibition constant: > 5800 nM
Compound 3: no number, only a limit; the forecaster's own chance of this, stated with the estimate: 10%; middle value at least 1.1-fold (0.06 log units) from the limit.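

Compound 3 gives only a limit of the assay, not a number: the limit of > 5800 nM in this assay, at which 1 of the 3 values shown sits. Replacing 1,3-dimethyl-1H-pyrazol-5-yl with 1H-pyrazol-1-yl gives an at least 1.5-fold higher number from compound 2 to compound 3 (0.19 log units; that floor lies within the scatter), so the true size of this change could be small or large. Among these compounds, replacing 1-ethyl-3-methyl-1H-pyrazol-5-yl with the same group gives an at least 2.7-fold higher number from compound 1 to compound 3 (0.44 log units; beyond the scatter), the first step here to clear the scatter, and it shows weaker inhibition with the bare ring.

Going by these compounds, it remains open whether losing the alkyl groups or moving the ring's point of attachment matters more. On these data alone, how an amine, a carboxylic acid or a longer chain such as propyl on this ring would read also remains open.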